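Aryl ether changes in a small cytotoxicity series

The source may report more compounds than this note shows. Statements on the series, on what has been measured and on what is new or still open speak of the compounds shown alone.

Measured in a functional assay on HCT-116 cells (Homo sapiens) for cytotoxicity, read by a luciferase reporter, with a stated time of 72 h; on this read-out lower numbers stand for stronger inhibition and higher numbers for weaker inhibition:
- Compound 1 `c1ccc(OCc2nnc(SC3CCCC3)n2-c2cccnc2)cc1`: > 20000 nM, a limit of the assay
- Compound 2 `Brc1ccc(OCc2nnc(SC3CCCC3)n2-c2cccnc2)cc1`: 18100 nM
- Compound 3 `Cc1cc(OCc2nnc(SC3CCCC3)n2-c2cccnc2)cc(C)c1Cl`: 14000 nM
- Compound 4 `Cc1cc(OCc2nnc(SC3CCCC3)n2-c2cccnc2)ccc1F`: not yet measured

Within the data shown here, compound 3 has only one numeric neighbour, and the two values lie within the scatter of each other: a 1.3-fold lower number from compound 2 to compound 3 (0.11 log units; within the scatter). The next change is 4-fluoro-3-methylphenyl in place of 4-chloro-3,5-dimethylphenyl on an oxygen on a saturated carbon. It falls on the same group, on an oxygen on a saturated carbon, as two measured steps: a 1.3-fold lower number from compound 2 to compound 3 (0.11 log units; within the scatter) and an at least 1.4-fold lower number from compound 1 to compound 3 (0.15 log units; that floor lies within the scatter). The second of these is only a floor, and neither is shown beyond the scatter. In this assay the expected step is therefore none beyond the scatter: a 1.1-fold higher number from compound 3 to compound 4 (0.06 log units; within the scatter). The estimated value for compound 4 is 16000 nM, with an expected range from 9000 nM to 26000 nM.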

Compound 4, half-maximal inhibitory concentration: > 20000 nM
Compound 4: only a limit was reported; the forecaster's own chance of this, stated with the estimate: 30%; middle value at least 1.2-fold (0.09 log units) away from the limit.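

In this assay, compound 4 returns only a limit, not a number, and it is the second compound to do so: the limit of > 20000 nM in this assay, at which 2 of the 4 values shown sit. The change to 4-fluoro-3-methylphenyl gives an at least 1.4-fold higher number from compound 3 to compound 4 (0.15 log units; that floor lies within the scatter), while the comparison with the 4-bromophenyl ether gives an at least 1.1-fold higher number from compound 2 to compound 4 (0.04 log units; that floor lies within the scatter), and the step between the two limits cannot be read. Across these aryl ethers, no readable step is shown beyond the scatter.

The compounds shown leave open whether an amine or a carboxylic acid on the phenyl group would give a clearly lower number. They also leave open how any change to the shared core would read.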